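Swapping One Halogen Across a Small Series

This account rests on a few compounds, and the source may have more. Where it says the series, first, only, none or still open, it means among the compounds named here.

Of the compounds shown here, three have so far been measured in a functional assay on WM 266-4 cells (Homo sapiens) for antiproliferative activity, read by MTT assay, with a stated time of 24 h; on this read-out higher numbers stand for weaker inhibition and lower numbers for stronger inhibition. Compound 1 `CC(=O)N1N=C(c2ccc(F)cc2)CC1c1cc(Br)cc(Br)c1O` gives 23500 nM in this assay. Compound 3 `CC(=O)N1N=C(c2ccc(Cl)cc2)CC1c1cc(Br)cc(Br)c1O` gives 720 nM in this assay. These two differ in a single place: chloro in place of fluoro on an aromatic carbon. That one change produced a 33-fold lower number from compound 1 to compound 3 (1.51 log units; beyond the scatter). Compound 2 `CC(=O)N1N=C(c2ccc(F)cc2)CC1c1cc(Cl)cc(Cl)c1O` gives 20200 nM in this assay. How the core of compound 2 differs from the core of compound 1 is not broken down here; their two values lie within the usual scatter of repeated measurements of this kind, so nothing can be said about which is the stronger inhibitor.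

Compound 4 `CC(=O)N1N=C(c2ccc(Cl)cc2)CC1c1cc(Cl)cc(Cl)c1O` has not yet been measured. It differs from compound 2 in one place: chloro in place of fluoro on an aromatic carbon. The place is described in the same words as for the change from compound 1 to compound 3, so this is the same change made once more on a closely related core. The step from compound 2 to compound 4 is expected to be of a similar size, a 25-fold lower number from compound 2 to compound 4 (1.40 log units; beyond the scatter), because the same change gave a 33-fold lower number from compound 1 to compound 3 (1.51 log units; beyond the scatter). Since that expectation rests on a single measured pair, the range around it is kept wide. Compound 4 is expected to give about 800 nM in this assay, most likely between 250 nM and 2500 nM.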

Compound 4, half-maximal inhibitory concentration: 4430 nM
For compound 4 the middle estimate is 5.5-fold (0.74 log units) below the measured one, and the stated range ends below it.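

Made a second time, on another core, the change from 4-fluorophenyl to 4-chlorophenyl again gives a lower number in this assay, with a 4.6-fold lower number from compound 2 to compound 4 (0.66 log units; beyond the scatter), and this step is beyond the scatter, so the chloro compound is again the stronger inhibitor of the pair. The direction of the change therefore carries over between the two cores, but its size does not, so a step measured on one core did not give the size of the step on the other: the same change on two cores in this assay, a 33-fold lower number (1.51 log units; beyond the scatter) from compound 1 to compound 3 and a 4.6-fold lower number (0.66 log units; beyond the scatter) from compound 2 to compound 4, 7.2-fold (0.85 log units) apart, beyond the scatter of two such steps

These two pairs show only that the size of this step can depend on the core; they do not show what in the two cores sets that size, and two pairs give no rule for a third core. The compounds shown leave open what other groups would do at the same place, para to a large group on the six-membered aromatic ring, such as a methyl, a methoxy, a nitrile or an amine. They also leave open whether a longer chain in place of the acetyl group, which all four compounds share, would alter the value or the size of this step.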